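Cytotoxicity notes on the aryl amide ester series

The source may hold more compounds than are shown below. What is called first, only, known or untested is meant among the compounds shown, and "the series" means these compounds.

The shared core of compound 1 `CCOC(=O)CCCCCOc1cccc(CN(C(=O)c2ccccc2)C(C)C)c1` carries a plain benzamide. In an ADME assay on HepG2 cells (Homo sapiens) for cytotoxicity, read by CellTiter-Glo and resazurin assay, with a stated time of 72 h (a higher number here means that more compound is needed for the effect, a lower number that less compound is needed), compound 1 gives > 26000 nM, which is a limit of the assay and not a number. Compound 2 `CCOC(=O)CCCCCOc1cccc(CN(C(=O)c2ccc(-c3ccc4ccccc4c3)cc2)C(C)C)c1` adds a naphthalen-2-yl group on an aromatic carbon. In this assay compound 2 gives > 26000 nM, again a limit. Compound 3 `CCOC(=O)CCCCCOc1cccc(CN(C(=O)c2ccc(-c3cccc(OCC(C)C)c3)cc2)C(C)C)c1` instead carries a 3-(isobutoxy)phenyl group. In this assay compound 3 gives > 26000 nM, also a limit, so compound 3 stands at the same limit as the rest of the series and no ordering among them can be read. The steps are unreadable: a step that the two limits leave unreadable from compound 1 to compound 2, a step that the two limits leave unreadable from compound 1 to compound 3 and a step that the two limits leave unreadable from compound 2 to compound 3. This follows because of the limit of > 26000 nM in this assay, at which 3 of the 3 values shown sit.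

Compound 4 `CCOC(=O)CCCCCOc1cccc(CN(C(=O)c2ccc(-c3ccc4[nH]ccc4c3)cc2)C(C)C)c1` is not yet measured. The change is 1H-indol-5-yl in place of 3-(isobutoxy)phenyl on an aromatic carbon. All three measured steps bear on this change, since each swaps one aryl group for another or for hydrogen on the same aromatic carbon, and none produced a readable effect. No step beyond the scatter is therefore expected; the step from compound 3 to compound 4 is estimated as a step that the limit leaves unreadable from compound 3 to compound 4. Compound 4 is expected to give about 40000 nM in this assay, within 15000 nM to 120000 nM, most likely reported once more only as a limit.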

Compound 4, half-maximal effective concentration: > 26000 nM
Compound 4 was reported as a limit (the forecaster's own chance of this, stated with the estimate: 80%); the middle value is on the limit's open side.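

In this assay compound 4 gives > 26000 nM, which is a limit of the assay. No new step can be read from compound 4 to compound 1, compound 2 or compound 3: the limit of > 26000 nM in this assay, at which 4 of the 4 values shown sit.

On these data alone, how these four compounds rank in this assay, and whether any group at this aromatic carbon changes the result, stays open.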